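The source may report more compounds than this note shows. Statements on the series, on what has been measured and on what is new or still open speak of the compounds shown alone.

Working notes on the series, values in a functional assay on SW620/5-FU cells (Homo sapiens) for cytotoxicity, read by MTT assay, with a stated time of 48 h, in the presence of a further agent that is not named here; a lower number here means that less compound is needed, a higher number that more compound is needed for the effect:
- compound 1 `CCCc1cc(NNC(=O)Nc2cc(Cl)nc(Cl)c2)nc2c1c(C)nn2C`: 40800 nM
- compound 2 `CCCc1cc(NNC(=O)Nc2cc(Cl)nc(Cl)c2)nc2c1cnn2C`: 38700 nM
- compound 3 `CCCc1cc(NNC(=O)Nc2cc(Cl)nc(Cl)c2)nc2c1c(C(F)(F)F)nn2C`: 11700 nM

Compound 1 stands at the high end of these numbers. Of its steps, a 1.1-fold lower number from compound 1 to compound 2 (0.02 log units; within the scatter) is within the scatter, while a 3.5-fold lower number from compound 1 to compound 3 (0.54 log units; beyond the scatter) is modest.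

Compound 4 `Cc1nn(C)c2nc(NNC(=O)Nc3cc(Cl)nc(Cl)c3)cc(-c3ccc(Cl)s3)c12` has 5-chlorothiophen-2-yl in place of propyl on an aromatic carbon. For the measured compounds named here, no measured step changes this group, so the evidence is indirect. Only the sizes of a 3.5-fold lower number from compound 1 to compound 3 (0.54 log units; beyond the scatter) and a 3.3-fold lower number from compound 2 to compound 3 (0.52 log units; beyond the scatter) offer a guide, and the direction remains uncertain.

A modest step is expected: a 2.0-fold lower number from compound 1 to compound 4 (0.31 log units; beyond the scatter). For compound 4 the estimated value is 20000 nM, with an expected range of 6000 nM to 60000 nM.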

Compound 4, half-maximal effective concentration: 29400 nM
For compound 4 the middle estimate is 1.5-fold (0.17 log units) below the measured one; the measured number falls inside the stated range.
By their numbers in this assay, from the lowest: compound 3; then compounds 4, 2 and 1 (each within the scatter of the next).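

In this assay, for the compounds shown here, the earlier steps all kept propyl in place, so this is the first reading at the position opposite the ring nitrogen. Exchanging the open chain for 5-chlorothiophen-2-yl, a five-membered aromatic ring, gives a 1.4-fold lower number from compound 1 to compound 4 (0.14 log units; within the scatter), so this change does not separate the two compounds. No available measurement offers an explanation for this result.

From the compounds shown here alone, it remains open whether an amine, a carboxylic acid or a longer chain at this position would separate from propyl. Also open, going by these compounds, is whether the trifluoromethyl step seen with propyl carries over to compounds bearing 5-chlorothiophen-2-yl.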